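This account rests on a few compounds, and the source may have more. Where it says the series, first, only, none or still open, it means among the compounds named here.

Three members of the series have been run in an ADME assay on HEK293 cells (Homo sapiens) for cytotoxicity, read by MTT assay, with a stated time of 44 h; a lower number here means a stronger inhibitor, a higher number a weaker inhibitor. Compound 1 `CCC1(c2cccc(Br)c2)ON=C(c2ccccc2Cl)O1` gives in this assay > 100000 nM, which is a limit of the assay rather than a number. Compound 2 `CCC1(c2cccc(Cl)c2)ON=C(c2cccc(Cl)c2)O1` gives in this assay > 100000 nM, again only a limit. Compound 3 `CC1(c2cccc(Br)c2)ON=C(c2cccc(Cl)c2)O1` gives in this assay > 100000 nM, once more a limit and not a measured figure. Where compound 3 stands is thus known only as a limit, and the two other values shown are limits as well; all three sit together at the limit of > 100000 nM in this assay, at which 3 of the 3 values shown sit. Among the measured compounds shown here, no two measured compounds differ in a single place, so no step can be read from the numbers in hand.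

The next compound, compound 4 `CCC1(c2cccc(Br)c2)ON=C(c2cccc(Cl)c2)O1`, differs from compound 3 in one place: methyl in place of hydrogen on a saturated chain carbon bound to a saturated ring carbon; cut one bond further out, the same difference reads methyl to ethyl. With every measured value resting at the limit, no step beyond the scatter is expected from this change in this assay. The estimated step is a step that the limit leaves unreadable from compound 3 to compound 4, meaning little or no change, with the reading most probably a limit again. Compound 4 is expected to give in this assay about 150000 nM, within a range of 50000 nM to 500000 nM.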

Compound 4, half-maximal inhibitory concentration: > 100000 nM
Compound 4 ended at the assay's limit (the forecaster's own chance of this, stated with the estimate: 85%); the middle value lies beyond the limit too.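

Compound 4 sits at a limit, as do compound 1, compound 2 and compound 3, so the steps to compound 4 from these three cannot be read in this assay: the limit of > 100000 nM in this assay, at which 4 of the 4 values shown sit.

The compounds shown leave open whether methyl in place of hydrogen, bromo in place of chloro, or 3-chlorophenyl in place of 2-chlorophenyl changes anything in this assay, and whether any member of the series gives a measured figure there.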